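The source may report more compounds than this note shows. Statements on the series, on what has been measured and on what is new or still open speak of the compounds shown alone.

Compounds measured so far:

Compound 1, `COc1ccc(/C=C\c2cc(OC)c(OC)c(OC)c2)cc1OCc1ccc(CN2C[C@H](O)C[C@@H]2C(=O)O)cc1`: in a functional assay on B16-F10 cells (Mus musculus) for antiproliferative activity, read by CCK-8 assay, with a stated time of 48 h (a higher number here means a weaker inhibitor, a lower number a stronger inhibitor), compound 1 gives > 10000 nM, which is a limit of the assay rather than a number.
Compound 2, `COc1ccc(/C=C\c2cc(OC)c(OC)c(OC)c2)cc1OCc1ccc(CO)cc1`: in this assay compound 2 gives 6600 nM.

Compound 1 stands only at a limit, so its true value is not known; the limit of > 10000 nM in this assay, at which 1 of the 2 values shown sits, marks where it sits among the two values. The new compound 3, `COc1ccc(/C=C\c2cc(OC)c(OC)c(OC)c2)cc1OCc1ccc(CN2CC[C@@H](O)C2)cc1`, differs from compound 1 by the change (hydrogen in place of carboxy on a saturated ring carbon). Among the measured compounds shown here, the only measured step that bears on this is an at least 1.5-fold lower number from compound 1 to compound 2 (0.18 log units; that floor lies within the scatter), in which the whole 2-carboxy-4-hydroxypyrrolidin-1-yl group is replaced by hydroxy; its floor lies within the scatter, so it gives no clear sign of how much the carboxy alone contributes. Compound 3 keeps the 3-hydroxypyrrolidin-1-yl ring and loses only the carboxy, which is part of what compound 2 has lost. The step of an at least 1.2-fold lower number from compound 1 to compound 3 (0.09 log units; that floor lies within the scatter) is therefore expected to be small or none beyond the scatter. Compound 3 is estimated at 8000 nM, with a range from 2500 nM to 30000 nM, and a real chance that the assay again reports only a limit.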

Compound 3, half-maximal inhibitory concentration: > 10000 nM
Compound 3 ended at the assay's limit (the forecaster's own chance of this, stated with the estimate: 40%); middle value at least 1.2-fold (0.09 log units) from the limit.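

With the carboxy replaced by hydrogen on the saturated ring carbon, the compound still gives no number: in this assay compound 3 gives > 10000 nM and that is a limit of the assay. Compound 1 also stands at a limit, so the step between these two compounds cannot be read, and losing the carboxy is not shown to change the result in either direction: the limit of > 10000 nM in this assay, at which 2 of the 3 values shown sit. Among the compounds shown here, the one readable step, with 3-hydroxypyrrolidin-1-yl in place of hydroxy on the saturated chain carbon, is an at least 1.5-fold higher number from compound 2 to compound 3 (0.18 log units; that floor lies within the scatter) and so gives no clear sign that the ring costs anything beyond the scatter, although the true gap may be larger than this floor.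

The compounds shown leave open how far past the limit compound 1 and compound 3 really lie, and so whether the carboxy matters at all on this ring carbon. Also open, as far as these compounds go, is whether a simple dimethylamino group or a pyrrolidine ring without the hydroxy, on the same chain carbon, would give a value that can be read as a number.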